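The source may hold more compounds than are shown below. What is called first, only, known or untested is meant among the compounds shown, and "the series" means these compounds.

Compound 3, `O[C@@H](c1ccccc1)[C@H]1CO[C@H](c2ccccc2)[C@@H](C/C=C/c2cccc(F)c2)C1`, gives the lowest of the three numbers measured in a functional assay on HL-60 cells (Homo sapiens) for cytotoxicity, read by WST assay, with a stated time of 48 h (on this read-out lower numbers stand for stronger inhibition and higher numbers for weaker inhibition), with 9170 nM. Its nearest neighbour is compound 1, `Cc1ccc(/C=C/C[C@H]2C[C@@H]([C@@H](O)c3ccccc3)CO[C@@H]2c2ccccc2)cc1C`, which in this assay gives 9880 nM, and the furthest is compound 2, `Oc1cccc(/C=C/C[C@H]2C[C@@H]([C@@H](O)c3ccccc3)CO[C@@H]2c2ccccc2)c1`, which gives 12800 nM; both gaps lie within the scatter, so the three compounds cannot be ranked. Compound 4, `CCCCCC/C=C/C[C@H]1C[C@@H]([C@@H](O)c2ccccc2)CO[C@@H]1c1ccccc1`, differs from compound 3 in one place: hexyl in place of 3-fluorophenyl on a double-bonded chain carbon bound to a double-bonded chain carbon. The measured steps all swap one aryl group for another on the same chain carbon and were all small: a 1.3-fold higher number from compound 1 to compound 2 (0.11 log units; within the scatter), a 1.1-fold lower number from compound 1 to compound 3 (0.03 log units; within the scatter) and a 1.4-fold lower number from compound 2 to compound 3 (0.14 log units; within the scatter). None of them exchanges an aryl group for a chain, so the present change is not directly covered. Because a 1.1-fold lower number from compound 1 to compound 3 (0.03 log units; within the scatter) stayed within the scatter, as did the other two aryl swaps, compound 4 is expected to show a step of a 1.1-fold higher number from compound 3 to compound 4 (0.04 log units; within the scatter). Compound 4 is therefore estimated at 10000 nM, with a range of 4000 nM to 25000 nM.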

Compound 4, half-maximal inhibitory concentration: 4990 nM
For compound 4 the middle estimate is 2.0-fold (0.30 log units) above the measured one; low and high end bracket the measured number.
By their numbers in this assay, from the lowest: compounds 4, 3, 1 and 2 (each within the scatter of the next, the first and the last beyond it).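

In this assay, the chain carbon tolerates hexyl as well as an aryl group: the exchange for 3-fluorophenyl gives a 1.8-fold lower number from compound 3 to compound 4 (0.26 log units; within the scatter) and the exchange for 3,4-dimethylphenyl gives a 2.0-fold lower number from compound 1 to compound 4 (0.30 log units; within the scatter), so among these compounds an aromatic ring at this place is not needed to keep the number in this range. Among the compounds shown here, only the exchange for 3-hydroxyphenyl gives a step beyond the scatter, with a 2.6-fold lower number from compound 2 to compound 4 (0.41 log units; beyond the scatter), and it is the first such step at this position, though a modest one. Nothing shown here offers an explanation for these numbers.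

The compounds shown leave open whether a shorter chain, a longer chain, or a chain ending in an amine or a carboxylic acid would hold the same number at this place. They also leave open whether hexyl would give a similar number if the double bond were replaced by a saturated link.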